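The compounds below may be only part of what the source reports. "The series", "measured", "known", "first", "only" and "open" are said of these compounds alone.

Compound 1 `O=C1NC(=S)/C(=C/c2cccc(Cl)c2)S1` belongs to a small set of three compounds that share one core and differ only in the halogens on the aromatic ring. In a functional assay on HEp-2 cells (Homo sapiens) for cytotoxicity, read by MTT assay, with a stated time of 72 h, tested at 1.25 ug/mL (on this read-out lower numbers stand for less inhibition of growth and higher numbers for more inhibition of growth at the one concentration tested), compound 1 gives -0.36%, the highest of the three numbers, although its gap to compound 3 `O=C1NC(=S)/C(=C/c2ccc(Cl)c(Cl)c2)S1`, which gives -5.45%, lies within the scatter, while compound 2 `O=C1NC(=S)/C(=C/c2ccccc2Cl)S1` gives -11.3%. Among the compounds with values here, the only single-place step among them, a number 5.1 percentage points lower from compound 1 to compound 3 (within the scatter), changes nothing beyond the scatter.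

Compound 4 `O=C1NC(=S)/C(=C/c2cccc(Br)c2)S1` differs from compound 1 by bromo in place of chloro on an aromatic carbon. Within the data shown here, no measured step swaps one halogen for another, and all three measured numbers sit near zero, so the expected change is a number 1.6 percentage points lower from compound 1 to compound 4 (within the scatter), none beyond the scatter. Compound 4 is therefore estimated at -2%, between -12% and 8%.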

Compound 4, percent growth inhibition at one concentration: -5.3%
Estimate against measurement, compound 4: 3.3 percentage points above; low and high end bracket the measured number.
By their numbers in this assay, from the lowest: compounds 2, 3, 4 and 1 (each within the scatter of the next, the first and the last beyond it).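

Bromo in place of chloro on this aromatic carbon gives a number 4.9 percentage points lower from compound 1 to compound 4 (within the scatter), the first measured swap of one halogen for another. In this assay, this single pair therefore shows no difference between the two halogens at this place on the ring. Nothing available bears on the reason for this result.

From the compounds shown here alone, it remains open whether a group of another kind on the same carbon, such as an amine or a carboxylic acid, would move the number beyond the scatter. Going by these compounds, whether bromo on other carbons of the ring would match chloro there also remains open.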